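This account rests on a few compounds, and the source may have more. Where it says the series, first, only, none or still open, it means among the compounds named here.

Values in a functional assay on KB-V1 cells (Homo sapiens) for cytotoxicity, read by MTT assay, with a stated time of 72 h (a higher number here means a weaker inhibitor, a lower number a stronger inhibitor), for the series:
Compound 1 `O=C1Nc2ccccc2/C1=N/NC(=S)Nc1ccc(C(=O)O)cc1` gives > 50000 nM as a limit of the assay
Compound 2 `CCc1ccc(NC(=S)N/N=C2\C(=O)Nc3ccccc32)cc1` gives 1340 nM as a measured number

Among the compounds with values here, compound 2 is so far the only compound with a true number. Compound 3 `CC(C)c1ccc(NC(=S)N/N=C2\C(=O)Nc3ccccc32)cc1` carries isopropyl where compound 2 carries ethyl: methyl in place of hydrogen on a saturated chain carbon bound to an aromatic carbon and a saturated chain carbon is the whole change. Within the data shown here, the one measured step of an at least 37-fold lower number from compound 1 to compound 2 (1.57 log units; beyond the scatter) was large but exchanged carboxy for ethyl, a different change, so it sets no size for this one. No step beyond the scatter is expected in this assay here. The estimated step of a 1.3-fold lower number from compound 2 to compound 3 (0.13 log units; within the scatter) is expected to stay within it. For compound 3 the expected value is 1000 nM with an estimated range from 400 nM to 2500 nM for now.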

Compound 3, half-maximal inhibitory concentration: 1090 nM
Compound 3: the middle estimate sits 1.1-fold (0.04 log units) below what was measured, within the range that was stated.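

In this assay, within the data shown here, ethyl to isopropyl gives a 1.2-fold lower number from compound 2 to compound 3 (0.09 log units; within the scatter), so the added methyl on this saturated chain carbon leaves the number within the scatter, something the earlier compounds could not show. Isopropyl in place of carboxy on the aromatic carbon gives an at least 45-fold lower number from compound 1 to compound 3 (1.66 log units; beyond the scatter). Compound 1 stands at a limit of the assay, so that step is a bound and not a size: the limit of > 50000 nM in this assay, at which 1 of the 3 values shown sits.

Open, as far as these compounds go, is whether a longer chain such as butyl moves the number beyond the scatter. Also open, from the compounds shown here alone, is where an amine or a hydroxyl on that aromatic carbon would fall relative to carboxy and the two alkyl groups.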